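This account rests on a few compounds, and the source may have more. Where it says the series, first, only, none or still open, it means among the compounds named here.

Compound 1 `OC[C@H]1O[C@@H](n2cnc3c(NCc4cccc(Br)c4)ncnc32)[C@H](O)[C@@H]1O` stands at the edge of what can be read. In a functional assay on B16 cells (Mus musculus) for antiproliferative activity, with a stated time of 72 h (a higher number here means a weaker inhibitor, a lower number a stronger inhibitor), compound 1 gives > 166000 nM, which is a limit of the assay and not a number. Compound 2 `OC[C@H]1O[C@@H](n2cnc3c(NCc4ccc(F)c(Cl)c4)ncnc32)[C@H](O)[C@@H]1O` gives 167000 nM in this assay. The step that the limit leaves unreadable from compound 1 to compound 2 cannot be sized because of the limit of > 166000 nM in this assay, at which 1 of the 2 values shown sits. Compound 3 `Cc1cccc(CNc2ncnc3c2ncn3[C@@H]2O[C@H](CO)[C@@H](O)[C@H]2O)c1O` differs from compound 1 by 2-hydroxy-3-methylphenyl in place of 3-bromophenyl on a saturated chain carbon bound to a nitrogen on an aromatic ring. No measured step covers this change, and the only step shown is unreadable. Compound 3 is expected to sit near compound 1, the step that the limit leaves unreadable from compound 1 to compound 3 being no larger than the scatter. Compound 3 is estimated at 170000 nM, with a range from 80000 nM to 400000 nM.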

Compound 3, half-maximal inhibitory concentration: > 166000 nM
Compound 3 ended at the assay's limit (the forecaster's own chance of this, stated with the estimate: 50%); the middle value is on the limit's open side.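

The steps linking compound 3 with compound 1 and compound 2 cannot be read, because the values stop at a limit: the limit of > 166000 nM in this assay, at which 2 of the 3 values shown sit. The compounds shown leave open how far any of these groups changes the activity.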